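The source may report more compounds than this note shows. Statements on the series, on what has been measured and on what is new or still open speak of the compounds shown alone.

Working notes on the series. Compound 1 `CC[C@@H]1C(=O)N(C)c2cnc(-n3ccc4cc(F)ccc43)nc2N1C1CCCC1` carries the shared core with no amide on the outer ring. In a functional assay on HeLa cells (Homo sapiens) for antiproliferative activity, read by CCK-8 assay, with a stated time of 72 h (a lower number here means a stronger inhibitor of growth, a higher number a weaker inhibitor of growth), compound 1 is recorded as "not active" (no number reported). Compound 2 `CC[C@@H]1C(=O)N(C)c2cnc(Nc3ccc(S(=O)(=O)NCCO)cc3)nc2N1C1CCCC1` gives 459 nM in this assay. Compound 3 `CCCCNC(=O)c1ccc2c(ccn2-c2ncc3c(n2)N(C2CCCC2)[C@H](CC)C(=O)N3C)c1` gives 346 nM in this assay, a number that sits within the scatter of compound 2, so no order between the two can be read. Compound 4 `CCCNC(=O)c1ccc2c(ccn2-c2ncc3c(n2)N(C2CCCC2)[C@H](CC)C(=O)N3C)c1` is not yet measured in this assay. It differs from compound 3 by hydrogen in place of methyl on a saturated chain carbon, three bonds along the chain from an amide-type nitrogen, the same difference cut one bond further out reading butyl to propyl. With no measured step of this kind in the series, the expected step from compound 3 to compound 4 is a 1.2-fold higher number from compound 3 to compound 4 (0.06 log units; within the scatter), not beyond the scatter. Compound 4 is therefore expected to give about 400 nM, within 180 nM to 900 nM.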

Compound 4, concentration for 50% growth inhibition: 238 nM
For compound 4 the middle estimate is 1.7-fold (0.23 log units) above the measured one; low and high end bracket the measured number.
By their numbers in this assay, from the lowest: compounds 4, 3 and 2 (each within the scatter of the next).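

Among the compounds shown here, this is the only measured step at this chain position. In this assay, hydrogen in place of methyl, three bonds along the chain from an amide-type nitrogen, gives a 1.5-fold lower number from compound 3 to compound 4 (0.16 log units; within the scatter), so the butyl and propyl amides cannot be told apart here. No available measurement bears on this result. The compounds shown leave open how far this chain can be altered without moving the number beyond the scatter. As far as these compounds go, a longer chain such as hexyl, a shorter one such as ethyl, or a terminal amine or carboxylic acid remains untested among them.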